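Adding a Chloro Group on a Shared Benzylsulfanyl Core

The source may hold more compounds than are shown below. What is called first, only, known or untested is meant among the compounds shown, and "the series" means these compounds.

Compound 1, `COc1ccc(C2N=C(SCc3ccccc3)NC(C)=C2C(=O)Nc2ccc(Br)cc2)cc1`: 7.2%
Compound 2, `COc1ccc(C2N=C(SCc3ccccc3Cl)NC(C)=C2C(=O)Nc2ccc(Br)cc2)cc1`: 10.8%
Compound 3, `CC1=C(C(=O)Nc2ccc([N+](=O)[O-])cc2)C(c2ccc(Br)cc2)N=C(SCc2ccccc2)N1`: 21.1%

These three compounds were tested in a functional assay on the whole organism (artery, strain albino) with Rattus norvegicus as the target, with a stated time of 720 min, at a dose of 10 mg/kg by the oral route; on this read-out higher numbers stand for more inhibition at the one dose given (going by the name of the read-out) and lower numbers for less inhibition. Compound 1 and compound 2 share one core and differ in a single place: chloro in place of hydrogen on an aromatic carbon. On this read-out the result is a number 3.6 percentage points higher from compound 1 to compound 2 (within the scatter), so the two numbers cannot be told apart with confidence.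

Compound 3 is built on a different core; the difference between the two cores is not broken down here. What can be said is that compound 3 gives the highest of the three numbers, and its distance from both compound 2 and compound 1 lies beyond the usual scatter.

Compound 4, `CC1=C(C(=O)Nc2ccc([N+](=O)[O-])cc2)C(c2ccc(Br)cc2)N=C(SCc2ccccc2Cl)N1`, has not yet been measured. It stands to compound 3 as compound 2 stands to compound 1: chloro in place of hydrogen on an aromatic carbon. The place of the change is described in the same words for both pairs, so this is the same change made on the other core.

Among the compounds with values here, the expectation for compound 4 rests on the one earlier example of this change, a number 3.6 percentage points higher from compound 1 to compound 2 (within the scatter), which stayed within the scatter. The estimated step is therefore a number 2.9 percentage points higher from compound 3 to compound 4 (within the scatter), a small one. Within the data shown here, compound 4 is thus expected to give about 24% in this assay, with a likely range from 11% to 38%, the width reflecting that only a single prior example supports this expectation.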

Compound 4, a percentage reported as inhibition, in the whole organism at one dose (the size of the read-out at that dose, not a potency): 6.7%
Compound 4: the middle estimate sits 17.3 percentage points above what was measured; the measured number lies below the stated range.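

On the core of compound 3, the chloro group gives a number 14.4 percentage points lower from compound 3 to compound 4 (beyond the scatter) in this assay and so does not repeat the small, unclear step seen on the core of compound 1. The effect of this change therefore cannot simply be carried from one core to the other in this series, as the two steps show: the same change on two cores in this assay, a number 3.6 percentage points higher (within the scatter) from compound 1 to compound 2 and a number 14.4 percentage points lower (beyond the scatter) from compound 3 to compound 4, 18 percentage points apart, beyond the scatter of two such steps. This does not show which part of the core is responsible, since the two cores differ in more than one place, and each step rests on a single pair of compounds tested at one dose, so no general rule for either core can be drawn.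

The compounds shown leave open whether the lower number on the core of compound 3 is particular to chloro, or whether a fluoro group, an amine or a carboxylic acid on the same aromatic carbon would also give a lower number there. Within the data shown here, they also leave open how such groups would behave on the core of compound 1, where the chloro group gave no step that stands clear of the scatter.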